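Cytotoxicity notes on an oxadiazole amide pair

The compounds below may be only part of what the source reports. "The series", "measured", "known", "first", "only" and "open" are said of these compounds alone.

Measured so far:
compound 1 `O=C(Nc1nnc(-c2ccc(C(F)(F)F)cc2)o1)c1cccc(Cl)c1` — 17000 nM
compound 2 `O=C(Nc1ncc(-c2ccc(F)cc2)o1)c1ccc(Cl)cc1` — 2000 nM

In an ADME assay on PC-3 cells (Homo sapiens) for cytotoxicity, read by MTT assay (on this read-out higher numbers stand for weaker inhibition and lower numbers for stronger inhibition), compound 1 gives 17000 nM, the highest of the two numbers, while compound 2 gives 2000 nM, a gap well beyond the scatter. Compound 3 `O=C(Nc1nnc(-c2ccc(C(F)(F)F)cc2)o1)c1ccc(Cl)nc1` is not yet measured. It differs from compound 1 by 6-chloropyridin-3-yl in place of 3-chlorophenyl on a carbonyl carbon. Within the data shown here, no step of this kind has been measured, so from compound 1 to compound 3 in this assay no step beyond the scatter is expected, no change at the digits printed from compound 1 to compound 3 (within the scatter). For compound 3 an estimate of 17000 nM is made, with a range from 6000 nM to 50000 nM.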

Compound 3, half-maximal inhibitory concentration: > 25000 nM
Compound 3 gave a limit, no number; the forecaster's own chance of this, stated with the estimate: 20%; at least 1.4-fold (0.16 log units) between middle value and limit.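

Compound 3 gives > 25000 nM in this assay, which is a limit of the assay and not a number. On a carbonyl carbon, 6-chloropyridin-3-yl in place of 3-chlorophenyl gives an at least 1.4-fold higher number from compound 1 to compound 3 (0.16 log units; that floor lies within the scatter), so this change brings no stronger inhibition into view. The true size of the step cannot be read because the reading ends at a limit: the limit of > 25000 nM in this assay, at which 1 of the 3 values shown sits.

Still open, going by these compounds, is whether an amine or a carboxylic acid in place of the chlorine on the 6-chloropyridin-3-yl ring would give a lower number.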